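This account rests on a few compounds, and the source may have more. Where it says the series, first, only, none or still open, it means among the compounds named here.

Three compounds share one core and differ only in the group carried on a sulfur. Compound 1 `Cc1cc(N2CC[C@@H](C)[C@@H](N(C)c3ncnc4[nH]ccc34)C2)n2nc(SCC3CCCCC3)nc2n1` bears a cyclohexyl there, compound 2 `Cc1cc(N2CC[C@@H](C)[C@@H](N(C)c3ncnc4[nH]ccc34)C2)n2nc(SCc3ccccc3Br)nc2n1` a 2-bromophenyl, and compound 3 `Cc1cc(N2CC[C@@H](C)[C@@H](N(C)c3ncnc4[nH]ccc34)C2)n2nc(SCc3ccc([N+](=O)[O-])cc3)nc2n1` a 4-nitrophenyl, each on a saturated chain carbon bound to the sulfur. In a toxicity assay on GES1 cells (Homo sapiens) for inhibition, read by MTT assay, with a stated time of 72 h (a lower number here means a stronger inhibitor, a higher number a weaker inhibitor), compound 1 gives 98200 nM. Compound 2 reaches only a limit of this assay, > 100000 nM, so no number is known for it. Compound 3 gives 36600 nM, the lowest of the two numbers seen. The step of a 2.7-fold lower number from compound 1 to compound 3 (0.43 log units; beyond the scatter) is modest. The step of an at least 2.7-fold lower number from compound 2 to compound 3 (0.43 log units; beyond the scatter) is at least as large, its floor set by the limit of > 100000 nM in this assay, at which 1 of the 3 values shown sits.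

Compound 4 `C#CSc1nc2nc(C)cc(N3CC[C@@H](C)[C@@H](N(C)c4ncnc5[nH]ccc45)C3)n2n1` changes that group: ethynyl in place of 4-nitrobenzyl on a sulfur. Among the compounds with values here, none of the measured steps removes the ring altogether; they only exchange one ring for another and shift the number modestly. With the ring gone, the number is expected to rise back toward the level of compound 1. For compound 4 the expected step is a 2.0-fold higher number from compound 3 to compound 4 (0.31 log units; beyond the scatter). Compound 4 is therefore estimated at 75000 nM, within 25000 nM to 200000 nM.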

Compound 4, half-maximal inhibitory concentration: > 100000 nM
Compound 4: a limit, no number; the forecaster's own chance of this, stated with the estimate: 35%; middle value at least 1.3-fold (0.12 log units) from the limit.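

Earlier steps only exchanged one ring for another, whereas here the sulfur carries ethynyl with no ring at all, and the result is an at least 2.7-fold higher number from compound 3 to compound 4 (0.43 log units; beyond the scatter). Against cyclohexylmethyl the reading is an at least 1.0-fold higher number from compound 1 to compound 4 (0.00 log units; that floor lies within the scatter), which says little on its own, and the step between compound 2 and compound 4 cannot be read. Among the four compounds only compound 3 stands clearly lower, and the others cannot be ranked against each other with any confidence, as the top of the measurable range is reached: the limit of > 100000 nM in this assay, at which 2 of the 4 values shown sit.

Still open, from the compounds shown here alone, is whether the lower number of compound 3 goes with its nitro group or with the benzyl ring itself, which a plain benzyl would help separate. Also open, going by these compounds, is how a longer chain ending in an amine or a carboxylic acid would read on this sulfur.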